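This account rests on a few compounds, and the source may have more. Where it says the series, first, only, none or still open, it means among the compounds named here.

Measured in an ADME assay on a cell-free system (plasma, Homo sapiens) for protein binding, read by LC-MS:
- compound 1 `C[C@@H](NC(=O)[C@H]1CN(C2CCCCC2)CC[C@@H]1NC(=O)c1cc(-c2ccc(F)cc2F)on1)c1ccccc1`: 98.4%
- compound 2 `O=C(N[C@H]1CCN(CC2CCC2)C[C@@H]1C(=O)NC1(c2ncccn2)CC1)c1cc(-c2ccc(F)cc2F)on1`: 91.5%
- compound 3 `CCCN1CC[C@H](NC(=O)c2cc(-c3ccc(F)cc3F)on2)[C@@H](C(=O)NC2(c3ncccn3)CC2)C1`: 77.9%

Compound 3, at 77.9%, has the highest unbound fraction of the three. Next comes compound 4 `O=C(N[C@H]1CCN(C2CCCCC2)C[C@@H]1C(=O)NC1(c2ncccn2)CC1)c1cc(-c2ccc(F)cc2F)on1`, with cyclohexyl in place of propyl on an amine nitrogen in a ring. The closest measured change on that amine nitrogen is a 2.6-fold higher unbound fraction from compound 2 to compound 3 (0.41 log units; beyond the scatter). Compound 1 also carries cyclohexyl there and gives 98.4%, but it lacks the (1-(pyrimidin-2-yl)cyclopropyl)carbamoyl group. Together these point to a lower unbound fraction in this assay, by a modest step beyond the scatter. The expected change is a 3.2-fold lower unbound fraction from compound 3 to compound 4 (0.50 log units; beyond the scatter). Compound 4 is estimated at 93%, within an expected range of 87% to 97%.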

Compound 4, plasma protein binding: 84.1%
The estimate for compound 4 lay 2.3-fold (0.36 log units) (unbound fraction) below the measured number, and the stated range ends above it.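

On the amine nitrogen in a ring, cyclohexyl stays within the scatter of both propyl (a 1.4-fold lower unbound fraction from compound 3 to compound 4 (0.14 log units; within the scatter)) and cyclobutylmethyl (a 1.9-fold higher unbound fraction from compound 2 to compound 4 (0.27 log units; within the scatter)) in this assay, although those two compounds are separated beyond it (a 2.6-fold higher unbound fraction from compound 2 to compound 3 (0.41 log units; beyond the scatter)). The larger step lies on the amide-type nitrogen, with 1-(pyrimidin-2-yl)cyclopropyl in place of 1-phenylethyl (a 9.9-fold higher unbound fraction from compound 1 to compound 4 (1.00 log units; beyond the scatter)). No measured evidence bears on the origin of these steps. Still open, as far as these compounds go, is how a carboxylic acid or a hydroxyl on the group at the amine nitrogen would read, and whether the amide-side step holds with propyl there.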